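A few compounds are considered here, and "the series" means these few. Any claim that something is new, unique, unknown or untested is made for them only; others in the source may bear on it.

In a functional assay on PC-3 cells (Homo sapiens) for cytotoxicity, read by sulforhodamine B assay, with a stated time of 48 h (on this read-out lower numbers stand for stronger inhibition of growth and higher numbers for weaker inhibition of growth), compound 1 (`ClCc1ccc(Cn2cnc3c(Cl)ncnc32)cc1`) gives 4780 nM. Its isomer compound 2 (`ClCc1ccccc1Cn1cnc2ncnc(Cl)c21`) carries the same chloromethyl-bearing benzyl group and the same chloro-substituted core, and in this assay compound 2 gives 4460 nM. Compound 2 stands at the lowest of the two numbers, but compound 1 sits so close to it that the gap lies within the scatter, and no order between the two can be read from these figures.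

Compound 3 (`ClCc1ccccc1Cn1cnc2nc(Cl)nc(Cl)c21`) is not yet measured. It differs from compound 2 in a single place: chloro in place of hydrogen on an aromatic carbon. For the measured compounds named here, no measured pair shows what an added chloro at this place does on the shared core, so the expectation rests on compound 2 alone. Compound 3 is therefore expected to stay in the same neighbourhood as compound 2, with an estimated value of 3500 nM and a range from 1500 nM to 9000 nM. The expected step of a 1.3-fold lower number from compound 2 to compound 3 (0.11 log units; within the scatter) is small, towards a slightly lower number, and not clearly beyond the scatter.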

Compound 3, concentration for 50% growth inhibition: 750 nM
For compound 3 the middle estimate is 4.7-fold (0.67 log units) above the measured one; the whole stated range lies above it.
By their numbers in this assay, from the lowest: compound 3; then compounds 2 and 1 (each within the scatter of the next).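

In this assay, the aromatic carbon between two ring nitrogen atoms proves to be a place where the number can move: chloro in place of hydrogen there gives a 5.9-fold lower number from compound 2 to compound 3 (0.77 log units; beyond the scatter), a step beyond the scatter. Compound 1 and compound 2 both carry hydrogen at this carbon, so neither could show that this place matters at all. The change is small, only one heavy atom with no ring, no hydrogen-bond donors and no hydrogen-bond acceptors, yet it is enough to separate compound 3 from compound 2, and nothing measured here bears on what lies behind the step.

Chloro is the only group seen at this carbon, so it remains open whether fluoro, methyl, methoxy or an amine there would lower the number as well, keep it level with compound 2 or raise it. Going by these compounds, it is also open whether the same chloro would produce a step of similar size on the differently substituted benzyl group of compound 1, as one pair on one cell line cannot show whether the step carries over.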